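The source may report more compounds than this note shows. Statements on the series, on what has been measured and on what is new or still open speak of the compounds shown alone.

Compounds measured in a functional assay on MIA PaCa-2 cells (Homo sapiens) for inhibition, read by MTT assay, with a stated time of 48 h, tested at 10 uM; a lower number here means less inhibition of growth, a higher number more inhibition of growth at the concentration tested:
Compound 1 `C#CCOc1ccc(/C=C/C(=O)c2ccc(OC)cc2)cc1` gives 32%.
Compound 2 `O=C(/C=C/c1ccc(OCc2cn(Cc3ccccc3)nn2)cc1)c1ccc(Br)cc1` gives 44%.
Compound 3 `COc1ccc(C(=O)/C=C/c2ccc(OCc3cn(Cc4ccccc4)nn3)cc2)cc1` gives 68%.

Compound 3 stands highest of the three numbers in this assay; compound 2 lies nearest and compound 1 furthest, both gaps being beyond the scatter. For the measured compounds named here, the only single-place step among the measured compounds is a number 24 percentage points higher from compound 2 to compound 3 (beyond the scatter). Compound 4 `COc1ccc(C(=O)/C=C/c2ccc(OCc3cn(Cc4ccc(Br)cc4)nn3)cc2)cc1` keeps that methoxy and differs from compound 3 by bromo in place of hydrogen on an aromatic carbon, which read one bond further out is benzyl to 4-bromobenzyl. Going by the values given here, no measured step touches the benzyl group of the triazole, and the one step that involves a bromo concerns a different aromatic carbon, so it offers no direct guide for this change. With nothing in the measured numbers pointing either way, compound 4 is expected to stay close to compound 3 in this assay. For compound 4 the expected step is a number 3 percentage points lower from compound 3 to compound 4 (within the scatter), within the scatter. The estimate for compound 4 is therefore 65%, in a range from 45% to 85%.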

Compound 4, percent growth inhibition at one concentration: 56%
Compound 4: the middle estimate sits 9 percentage points above what was measured; the measured number falls inside the stated range.
By their numbers in this assay, from the lowest: compound 1; then compound 2; then compound 4; then compound 3.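

In this assay, for the compounds shown here, bromo in place of hydrogen on the benzyl group gives a number 12 percentage points lower from compound 3 to compound 4 (beyond the scatter), so this ring, which no earlier step touched, does not accept the change without a measurable shift. Going by these compounds alone, the one earlier step involving a bromo concerned a different aromatic carbon, whereas this step shows that growth inhibition at the concentration tested also responds to the group para to a large group on the benzyl ring, though compound 4 still gives 56%. Nothing measured alongside these numbers accounts for the lower value.

Only hydrogen and bromo are shown at this carbon, so it remains open whether an amine, a carboxylic acid or a methoxy there would read lower or higher. As far as these compounds go, it is also open whether the same change would give a similar step on compound 2, which carries bromo in place of the methoxy.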